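Sulfanyl for amino on the shared core: expectation

The source may report more compounds than this note shows. Statements on the series, on what has been measured and on what is new or still open speak of the compounds shown alone.

Compound 2 `Nc1nc2c(Cl)cc(Cl)cc2n1COCCO` is the parent of the step followed here. In a functional assay on KB cells (Homo sapiens) for inhibition (a lower number here means a stronger inhibitor, a higher number a weaker inhibitor), compound 2 gives only a limit, > 100000 nM. Compound 1 `OCCOCn1c(Cl)nc2c(Cl)c(Cl)ccc21` likewise gives a limit in this assay, > 100000 nM. Compound 3 `CNc1nc2c(Cl)c(Cl)ccc2n1COCCO` also gives a limit in this assay, > 100000 nM. Going by the values given here, the only single-point step measured, a step that the two limits leave unreadable from compound 1 to compound 3, is therefore unreadable, and the limit of > 100000 nM in this assay, at which 3 of the 3 values shown sit, summarises where all values rest.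

Compound 4 `OCCOCn1c(S)nc2c(Cl)cc(Cl)cc21` differs from compound 2 by sulfanyl in place of amino on an aromatic carbon. Among the compounds with values here, no measured step bears on this change, and the series offers no value that is not a limit. Compound 4 is expected to sit at 100000 nM, within 30000 nM to 300000 nM. The step of a number no higher from compound 2 to compound 4 (the limit leaves the size open) is estimated as none beyond the scatter, most probably another limit.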

Compound 4, half-maximal inhibitory concentration: > 100000 nM
Compound 4: no number, only a limit; the forecaster's own chance of this, stated with the estimate: 85%; the middle value sits exactly at the limit.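

Compound 2 and compound 4 both give only limits, so the step from amino to sulfanyl cannot be read. The compounds shown leave open whether any member of the series has a measurable inhibitory value: the limit of > 100000 nM in this assay, at which 4 of the 4 values shown sit.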